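The compounds below may be only part of what the source reports. "The series", "measured", "known", "first", "only" and "open" are said of these compounds alone.

Measured so far in a functional assay on BGC-823 cells (Homo sapiens) for antiproliferative activity, read by MTT assay, tested at 5 uM; on this read-out lower numbers stand for a weaker effect and higher numbers for a stronger effect at the one concentration tested:
compound 1 `COc1cc(C2=NN(C(C)=O)C(c3cccc(OC)c3OC)O2)cc(OC)c1OC` gives 17.5%;
compound 2 `COc1ccc(OC)c(C2OC(c3cc(OC)c(OC)c(OC)c3)=NN2C(C)=O)c1` gives 18.2%.

Among the measured compounds shown here, compound 2 stands beside compound 1 within the usual scatter, so the two numbers cannot be told apart; the one measured step, a number 0.7 percentage points higher from compound 1 to compound 2 (within the scatter), lies within the scatter. Compound 3 `COc1cc(C2=NN(C(C)=O)C(c3ccc(Cl)c(Cl)c3)O2)cc(OC)c1OC` is next. It differs from compound 2 in one place: 3,4-dichlorophenyl in place of 2,5-dimethoxyphenyl on a saturated ring carbon. For the measured compounds named here, the measured step swapped one dimethoxyphenyl for another; no step covers a 3,4-dichlorophenyl, so the guide is thin. No step beyond the scatter is expected in this assay, in either direction. Compound 3 is estimated at 20%, between 5% and 40%, an expected step of a number 1.8 percentage points higher from compound 2 to compound 3 (within the scatter).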

Compound 3, a percentage reported as inhibition, at one concentration (the size of the read-out at that concentration, not a potency): 3.1%
For compound 3 the middle estimate is 16.9 percentage points above the measured one; measured number outside the range, below it.
By their numbers in this assay, from the lowest: compound 3; then compounds 1 and 2 (each within the scatter of the next).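

In this assay the group on this saturated ring carbon does matter: 3,4-dichlorophenyl brings a number 15.1 percentage points lower from compound 2 to compound 3 (beyond the scatter) and a number 14.4 percentage points lower from compound 1 to compound 3 (beyond the scatter) as well. Moving the methoxy groups around the phenyl ring had shown no such sensitivity, so the change of group, not the choice of dimethoxyphenyl, separates these compounds. Nothing at hand explains the drop. As far as these compounds go, whether it follows from the two chlorines arriving or the two methoxy groups leaving stays open, as does what a plain phenyl, a single chlorine or an aminophenyl would give at this carbon.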